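Swapping methyl for chloro on the phenol ring

The source may hold more compounds than are shown below. What is called first, only, known or untested is meant among the compounds shown, and "the series" means these compounds.

Measured compounds:
- compound 1, `C/C(=N\NC(=O)c1cc(-c2ccccc2)nn1Cc1ccc(C(C)(C)C)cc1)c1cc(Cl)ccc1O`: 2770 nM
- compound 2, `C/C(=N\NC(=O)c1cc(-c2ccc(Cl)cc2)nn1Cc1ccc(C(C)(C)C)cc1)c1cc(Cl)ccc1O`: 280 nM
- compound 3, `COc1ccc(-c2cc(C(=O)N/N=C(\C)c3cc(C)ccc3O)n(Cc3ccc(C(C)(C)C)cc3)n2)cc1`: 10400 nM

In a functional assay on A549 cells (Homo sapiens) for inhibition, read by MTT assay, with a stated time of 48 h (on this read-out higher numbers stand for weaker inhibition and lower numbers for stronger inhibition), compound 3 gives 10400 nM, the highest number of the three, so it is the weakest inhibitor shown. Compound 4, `COc1ccc(-c2cc(C(=O)N/N=C(\C)c3cc(Cl)ccc3O)n(Cc3ccc(C(C)(C)C)cc3)n2)cc1`, has not yet been measured. It differs from compound 3 in one place: chloro in place of methyl on an aromatic carbon. Among the compounds with values here, only one measured step bears on this: a 9.9-fold lower number from compound 1 to compound 2 (1.00 log units; beyond the scatter), where the chloro enters on a different ring from the one changed here. Compound 1, which carries chloro on the phenol ring but no methoxy on the other ring, gives 2770 nM against compound 3 with 10400 nM, but two groups differ between them, so no single step can be read from that pair. On this basis a drop beyond the scatter is expected, though smaller than the step shown, because the place differs from that of a 9.9-fold lower number from compound 1 to compound 2 (1.00 log units; beyond the scatter). Compound 4 is therefore estimated at 3500 nM, between 1200 nM and 10000 nM, a step of a 3.0-fold lower number from compound 3 to compound 4 (0.47 log units; beyond the scatter).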

Compound 4, half-maximal inhibitory concentration: 9620 nM
Compound 4: middle estimate off by 2.7-fold (0.44 log units), on the low side; measured number inside the range.
By their numbers in this assay, from the lowest: compound 2; then compound 1; then compounds 4 and 3 (each within the scatter of the next).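

In this assay, methyl and chloro at this place, para to a hydroxy group, read alike while methoxy sits on the other ring (a 1.1-fold lower number from compound 3 to compound 4 (0.03 log units; within the scatter)). The group on that other ring counts for far more: methoxy in place of chloro gives a 34-fold higher number from compound 2 to compound 4 (1.54 log units; beyond the scatter), and methoxy in place of hydrogen gives a 3.5-fold higher number from compound 1 to compound 4 (0.54 log units; beyond the scatter), with 5-chloro-2-hydroxyphenyl kept throughout. No measurement shown here explains these differences.

Whether methyl and chloro would also read alike with hydrogen or chloro on the other ring remains open, since compound 1 and compound 2 have no methyl partner among the compounds shown. As far as these compounds go, how an amine or a carboxylic acid would read at this place is also open.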